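Trading naphthalen-1-yl for 3-chlorophenyl

The source may report more compounds than this note shows. Statements on the series, on what has been measured and on what is new or still open speak of the compounds shown alone.

Compound 1 `Cn1cncc1C(OCc1ccc(C#N)cc1-c1ccc(F)c(Cl)c1)c1ccc(C#N)nc1` gives 46 nM
Compound 2 `Cn1cncc1C(OCc1ccc(C#N)cc1-c1cccc2ccccc12)c1ccc(C#N)nc1` gives 46 nM
Compound 3 `Cn1cncc1C(OCc1nc(N2CCC(C(N)=O)CC2)c(C#N)cc1-c1cccc(Cl)c1)c1ccc(C#N)cc1` gives 1.5 nM

In a functional assay on NIH3T3 cells (Mus musculus) (on this read-out lower numbers stand for an effect already at smaller amounts and higher numbers for an effect only at larger amounts of compound), compound 2 stands level with compound 1, and together they hold the highest of the three numbers. Compound 3 sits much lower at 1.5 nM and also carries 3-chlorophenyl, but its core differs, so its number cannot be read across to this step.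

Compound 4 `Cn1cncc1C(OCc1ccc(C#N)cc1-c1cccc(Cl)c1)c1ccc(C#N)nc1` keeps the core of compound 2 and has 3-chlorophenyl in place of naphthalen-1-yl on an aromatic carbon. Among the compounds with values here, one measured step bears on this change at the same carbon, where naphthalen-1-yl replaced 3-chloro-4-fluorophenyl with no change at the digits printed from compound 1 to compound 2 (within the scatter) as the result. The group in compound 1 is a close relative of the entering 3-chlorophenyl, so a similar number seems likely. The estimated 1.2-fold lower number from compound 2 to compound 4 (0.08 log units; within the scatter) is small, and no step beyond the scatter is expected. In this assay the expected value for compound 4 is 38 nM within an estimated range of 14 nM to 105 nM and awaits measurement.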

Compound 4, half-maximal effective concentration: 2.1 nM
Estimate against measurement, compound 4: 18-fold (1.26 log units) above; the measured number lies below the stated range.
By their numbers in this assay, from the lowest: compounds 3 and 4 (each within the scatter of the next); then compounds 1 and 2 (each within the scatter of the next).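

At this aromatic carbon, the earlier level pair of compounds hid how much the choice of group can matter: in this assay, 3-chlorophenyl in place of naphthalen-1-yl gives a 22-fold lower number from compound 2 to compound 4 (1.34 log units; beyond the scatter) at the same core. Hydrogen in place of fluoro on that aryl group gives a 22-fold lower number from compound 1 to compound 4 (1.34 log units; beyond the scatter), so a single fluoro separates a high number from a low one, and the match between compound 1 and compound 2 did not mean that this place tolerates any group. Nothing measured here explains why these steps are so large.

The compounds shown leave open whether the chloro is needed at all, as a plain phenyl would tell, and whether a methyl or methoxy in its place would keep the low number. They also leave open whether an amine or hydroxyl where compound 1 carries fluoro would give a high number too.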